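Acyl urea thiazole hydrazones: the dichlorophenyl to difluorophenyl step

The source may report more compounds than this note shows. Statements on the series, on what has been measured and on what is new or still open speak of the compounds shown alone.

The series shares one core, seen in compound 1 `CN(C(=O)NC(=O)c1ccc([N+](=O)[O-])cc1)c1nc(C(F)(F)F)c(C(=O)N/N=C/c2cccc(C(F)(F)F)c2)s1`, compound 2 `CN(C(=O)NC(=O)c1ccc(Cl)cc1Cl)c1nc(C(F)(F)F)c(C(=O)N/N=C/c2ccc(C(F)(F)F)cc2)s1` and compound 3 `Cc1nc(N(C)C(=O)NC(=O)c2ccc(Cl)cc2Cl)sc1C(=O)N/N=C/c1ccc(C(F)(F)F)cc1`. In a functional assay on A549 cells (Homo sapiens) for inhibition, read by MTT assay, with a stated time of 72 h (on this read-out higher numbers stand for weaker inhibition and lower numbers for stronger inhibition), compound 1 gives 5.42 ug/mL, compound 2 gives 9.4 ug/mL and compound 3 gives 30.2 ug/mL. Within the data shown here, compound 2 thus stands second highest of the three numbers; its gap to compound 1 lies within the scatter, while the only one-place step in the set, a 3.2-fold higher number from compound 2 to compound 3 (0.51 log units; beyond the scatter), lies beyond it and concerns a different part of the molecule.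

Compound 4 `CN(C(=O)NC(=O)c1c(F)cccc1F)c1nc(C(F)(F)F)c(C(=O)N/N=C/c2ccc(C(F)(F)F)cc2)s1` is not yet measured. It differs from compound 2 in one place: 2,6-difluorophenyl in place of 2,4-dichlorophenyl on a carbonyl carbon. Among the measured compounds shown here, no measured step touches this carbonyl-bound aryl group directly. The only hint is indirect: compound 1 carries a different aryl group at that position and also differs in the aldehyde-derived ring, yet its number and that of compound 2 lie within the scatter of each other, so the aryl group on this carbonyl has so far not moved the read-out beyond noise.

Given that, the step of a 1.1-fold higher number from compound 2 to compound 4 (0.03 log units; within the scatter) is expected to stay within the scatter, with no clear direction. Compound 4 is expected to give about 10 ug/mL, between 4 ug/mL and 25 ug/mL.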

Compound 4, half-maximal inhibitory concentration: 40.1 ug/mL
Beside the measured number, compound 4's estimate is 4.0-fold (0.60 log units) below it; the whole stated range lies below it.
By their numbers in this assay, from the lowest: compounds 1 and 2 (each within the scatter of the next); then compounds 3 and 4 (each within the scatter of the next).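

In this assay, the aryl group on the carbonyl carbon is now shown to be a place where the read-out can move: a 4.3-fold higher number from compound 2 to compound 4 (0.63 log units; beyond the scatter), and this is the first one-place step measured there. The two groups compared have the same heavy-atom count and no hydrogen-bond donors or acceptors, so those counts do not distinguish them, and this position joins the aromatic carbon carrying trifluoromethyl as a second place where a one-place change away from compound 2 gives a higher number, the other step being a 3.2-fold higher number from compound 2 to compound 3 (0.51 log units; beyond the scatter). The data shown offer no measured property that would account for the step at the carbonyl-bound aryl group.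

Going from 2,4-dichlorophenyl to 2,6-difluorophenyl changes both the halogen and its placement on the ring, and this single step cannot separate the two changes or show whether either alone is enough. Also open, from the compounds shown here alone, is how this position behaves with an unsubstituted phenyl group or a methoxyphenyl group, and whether the step from compound 2 holds when the rest of the molecule differs.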